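From furan-2-yl to methyl on the shared core

The source may hold more compounds than are shown below. What is called first, only, known or untested is meant among the compounds shown, and "the series" means these compounds.

Among the compounds with values here, in a functional assay on HeLa S3 cells (Homo sapiens) for cytotoxicity, read by XTT assay, with a stated time of 6 days (on this read-out lower numbers stand for stronger inhibition and higher numbers for weaker inhibition), compound 3 `c1coc(-c2ncnc3[nH]cc(Sc4cccs4)c23)c1` gives 8490 nM, the lower of the two true numbers so far. Compound 2 `CNc1ncnc2[nH]cc(Sc3cccs3)c12` gives 17600 nM, which makes for a 2.1-fold lower number from compound 2 to compound 3 (0.32 log units; beyond the scatter). Compound 1 `CN(C)c1ncnc2[nH]cc(Sc3cccs3)c12` reaches only a limit of the assay, > 25000 nM.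

Compound 4 `Cc1ncnc2[nH]cc(Sc3cccs3)c12` has not yet been measured. It carries methyl in place of furan-2-yl on an aromatic carbon, the carbon where the three measured compounds also differ: methyl in place of furan-2-yl on an aromatic carbon.

Within the data shown here, no measured compound carries methyl, so the expectation rests on the steps at this carbon. Furan-2-yl gave the lower number in both steps that introduce it: the one already given for compound 2, and an at least 2.9-fold lower number from compound 1 to compound 3 (0.46 log units; beyond the scatter). The remaining step, an at least 1.4-fold lower number from compound 1 to compound 2 (0.15 log units; that floor lies within the scatter), has a floor within the scatter and adds little.

With furan-2-yl leaving, a modest move in the opposite direction seems most likely, similar in size to the step from compound 2, though a methyl group has not been tested here. The expected change is a 1.8-fold higher number from compound 3 to compound 4 (0.25 log units; within the scatter). For compound 4 the estimated value in this assay is 15000 nM, with an expected range from 6500 nM to 25000 nM.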

Compound 4, half-maximal inhibitory concentration: > 25000 nM
Compound 4 ended at the assay's limit (the forecaster's own chance of this, stated with the estimate: 25%); middle value at least 1.6-fold (0.22 log units) away from the limit.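

Within the data shown here, replacing furan-2-yl with methyl on this aromatic carbon gives, in this assay, an at least 2.9-fold higher number from compound 3 to compound 4 (0.46 log units; beyond the scatter), so the advantage of furan-2-yl now shows against a small carbon group as well as against the methylamino and dimethylamino groups of the earlier compounds. Against compound 2 the change gives an at least 1.4-fold higher number from compound 2 to compound 4 (0.15 log units; that floor lies within the scatter), a floor that does not separate methyl from methylamino on this carbon, and the step between compound 1 and compound 4 cannot be read. Methyl and dimethylamino therefore cannot be placed in any order, and compound 4 offers a limit rather than a number: the limit of > 25000 nM in this assay, at which 2 of the 4 values shown sit.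

On these data alone, whether the lower number of compound 3 goes with the aromatic ring of furan-2-yl, with its oxygen or simply with its larger size on this carbon stays open, and a phenyl group or a longer chain such as propyl at the same place would help to tell these apart. As far as these compounds go, how far the true value of compound 4 lies beyond its limit also remains unknown, so the full size of the change from furan-2-yl to methyl stays open.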